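Heteroaryl swap on the chain carbon: furan to thiophene

The compounds below may be only part of what the source reports. "The series", "measured", "known", "first", "only" and "open" are said of these compounds alone.

The shared core carries a saturated chain carbon bound to an aromatic nitrogen, and the group on that carbon is what varies. For the measured compounds named here, compound 1 `C#CCn1nnc2c(C(N)=O)ncn2c1=O` is the only member with a number: in a functional assay on SNB-19 cells (Homo sapiens) for inhibition, read by MTT assay, with a stated time of 7 days (on this read-out higher numbers stand for weaker inhibition of growth and lower numbers for stronger inhibition of growth), compound 1 gives 35600 nM. Compound 2 `NC(=O)c1ncn2c(=O)n(Cc3ccccc3)nnc12` reaches only the limit of the assay, > 50000 nM, in this assay. Compound 3 `NC(=O)c1ncn2c(=O)n(Cc3ccco3)nnc12` also stands at a limit, > 50000 nM, in this assay, one of the two values at the limit of > 50000 nM in this assay, at which 2 of the 3 values shown sit. The steps read an at least 1.4-fold higher number from compound 1 to compound 2 (0.14 log units; that floor lies within the scatter) and an at least 1.4-fold higher number from compound 1 to compound 3 (0.14 log units; that floor lies within the scatter), while a step that the two limits leave unreadable from compound 2 to compound 3. Compound 4 `NC(=O)c1ncn2c(=O)n(Cc3cccs3)nnc12` differs from compound 3 by thiophen-2-yl in place of furan-2-yl on a saturated chain carbon bound to an aromatic nitrogen. Going by the values given here, the one step that bears directly on it, a step that the two limits leave unreadable from compound 2 to compound 3, has no readable size, and both aryl replacements from compound 1 ended at the limit, so nothing beyond the scatter is expected. The expected step is a step that the limit leaves unreadable from compound 3 to compound 4. Compound 4 is estimated at 60000 nM in this assay, with a range from 30000 nM to 150000 nM, and most probably it is again reported only as a limit.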

Compound 4, concentration for 50% growth inhibition: > 50000 nM
Compound 4 ended at the assay's limit; the forecaster's own chance of this, stated with the estimate: 75%; the middle value is on the limit's open side.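

Compound 4 gives > 50000 nM in this assay as a limit of the assay, so phenyl, furan-2-yl and thiophen-2-yl on the saturated chain carbon bound to an aromatic nitrogen all end at a limit, and exchanging oxygen for sulfur in the five-membered aromatic ring yields no number. The steps from compound 2 and from compound 3 to compound 4 cannot be read, and an at least 1.4-fold higher number from compound 1 to compound 4 (0.14 log units; that floor lies within the scatter) is the only one with a readable floor. The series now gathers at one end of the scale: the limit of > 50000 nM in this assay, at which 3 of the 4 values shown sit.

On these data alone, whether any group at this place separates from compound 1 beyond the scatter remains open. An amine or a carboxylic acid on the chain carbon, or a longer chain ending in ethynyl, would test this.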